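From compound 2 to compound 4: a phenyl enters

A few compounds are considered here, and "the series" means these few. Any claim that something is new, unique, unknown or untested is made for them only; others in the source may bear on it.

Values measured in a functional assay on H460/TaxR cells (Homo sapiens) for cytotoxicity, read by sulforhodamine B assay, with a stated time of 48 h; a lower number here means that less compound is needed, a higher number that more compound is needed for the effect:
- Compound 1 `CN(C)c1ccc(/C=C2/SC(=Nc3ccccc3)NC2=O)cc1`: 980 nM
- Compound 2 `CN1CCN(c2ccc(/C=C3/SC(Nc4ccccc4)=NC3=O)cc2)CC1`: 2500 nM
- Compound 3 `O=C1N=C(Nc2ccccc2)S/C1=C/c1ccc(N2CCNCC2)cc1`: > 100000 nM, a limit of the assay

Among the two values that are actual numbers, compound 2 has the higher, at 2500 nM. Going by the values given here, the only other number belongs to compound 1, at 980 nM, and the gap between them lies beyond the scatter. Compound 3 gives no number, only (the limit of > 100000 nM in this assay, at which 1 of the 3 values shown sits).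

Compound 4 `CN1CCN(c2ccc(/C=C3/SC(N(c4ccccc4)c4ccccc4)=NC3=O)cc2)CC1` has not yet been measured. It differs from compound 2 by one change: phenyl in place of hydrogen on a nitrogen on an aromatic ring.

One measured step is available, an at least 40-fold higher number from compound 2 to compound 3 (1.60 log units; beyond the scatter), a large step for hydrogen in place of methyl on an amine nitrogen in a ring. That step lies at a different nitrogen, so it does not bear directly on this change. Among the compounds with values here, it shows only that one small change can move the number far, which argues for a wide range. A moderate move towards a higher number is therefore expected, though with little certainty. The expected change is a 1.6-fold higher number from compound 2 to compound 4 (0.20 log units; within the scatter). In this assay, the estimated value for compound 4 is 4000 nM, with an expected range from 600 nM to 30000 nM.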

Compound 4, half-maximal effective concentration: > 100000 nM
Compound 4: a limit, no number (the forecaster's own chance of this, stated with the estimate: 15%); at least 25-fold (1.39 log units) between middle value and limit.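

In this assay, going by these compounds alone, the earlier compounds said nothing about this nitrogen on an aromatic ring, since compound 2 and compound 3 both carry hydrogen there. This position turns out to be sensitive: phenyl in place of hydrogen gives an at least 40-fold higher number from compound 2 to compound 4 (1.60 log units; beyond the scatter), a large step. The value of compound 4 is a limit and not a number, so the step gives only a minimum size, and this nitrogen becomes the second place in the series, after the amine nitrogen in the ring of compound 3, where a single change ends in the same limit: the limit of > 100000 nM in this assay, at which 2 of the 4 values shown sit.

What methyl or ethyl on this nitrogen would do remains open, so the compounds shown cannot tell whether any carbon group in place of the hydrogen leads to the limit, or only one as large as phenyl. Also open, on these data alone, is whether a second phenyl carrying a methoxy group or a fluorine atom would bring back a measurable number in this assay, and how far the true value of compound 4 lies past its limit.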